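This account rests on a few compounds, and the source may have more. Where it says the series, first, only, none or still open, it means among the compounds named here.

In a functional assay on NALM-6 cells (Homo sapiens) (on this read-out lower numbers stand for stronger inhibition and higher numbers for weaker inhibition), compound 1 `CCCCCCCCCCSC[C@H](NC(C)=O)C(=O)CCl` gives 4700 nM, and compound 2 `CCCCCCCCCCCCCCCSC[C@H](NC(C)=O)C(=O)CCl` gives 8900 nM. Within the data shown here, compound 2 stands at the top of the two numbers so far, but the step of a 1.9-fold higher number from compound 1 to compound 2 (0.28 log units; within the scatter) lies within the scatter, so the two compounds cannot be separated on this read-out. Compound 3 `CCCCCCCCCCCCCCCCCCCCSC[C@H](NC(C)=O)C(=O)CCl` has not yet been measured in this assay. Compound 3 differs from compound 2 by pentyl in place of hydrogen on a saturated chain carbon, ten or more bonds along the chain from a sulfur. Among the measured compounds shown here, the only measured step that bears on this change, a 1.9-fold higher number from compound 1 to compound 2 (0.28 log units; within the scatter), adds the same group at the same kind of place along the chain and did not move the number beyond the scatter. On that basis, in this assay a small drift towards a higher number, or no change beyond the scatter, is expected for compound 3. Compound 3 is therefore estimated at 13000 nM, with a range from 5000 nM to 35000 nM. The step expected is a 1.5-fold higher number from compound 2 to compound 3 (0.16 log units; within the scatter).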

Compound 3, half-maximal inhibitory concentration: > 100000 nM
Compound 3 ended at the assay's limit; the forecaster's own chance of this, stated with the estimate: 15%; middle value at least 7.6-fold (0.88 log units) from the limit.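

In this assay compound 3 gives > 100000 nM, which is a limit of the assay and not a number: the limit of > 100000 nM in this assay, at which 1 of the 3 values shown sits.

The same change, pentyl in place of hydrogen on a saturated chain carbon, ten or more bonds along the chain from a sulfur, gave a 1.9-fold higher number from compound 1 to compound 2 (0.28 log units; within the scatter), but now gives an at least 11-fold higher number from compound 2 to compound 3 (1.05 log units; beyond the scatter), so among these three compounds the effect of adding to the chain is not even from one addition to the next. Taken as a single change, decyl in place of hydrogen gives an at least 21-fold higher number from compound 1 to compound 3 (1.32 log units; beyond the scatter), and the early flat stretch did not predict this.

Where between compound 2 and compound 3 the number starts to climb, and how far it climbs, stays open. Also open, going by these compounds, is whether an amine or a carboxylic acid in place of the pentyl of compound 3 would behave in the same way.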